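Adding a chloro to the amide's outer ring

The source may hold more compounds than are shown below. What is called first, only, known or untested is meant among the compounds shown, and "the series" means these compounds.

compound 1 `O=C(Nc1cccc(-n2cc(-c3ccncc3)c(-c3ccc(Cl)c(O)c3)n2)c1)Nc1cccc(C(F)(F)F)c1` gives 7900 nM
compound 2 `COc1cc(-c2nn(-c3cccc(NC(=O)Nc4cc(C(F)(F)F)cc(C(F)(F)F)c4)c3)cc2-c2ccncc2)ccc1Cl` gives 847 nM
compound 3 `COc1cc(-c2nn(-c3cccc(NC(=O)c4cccc(C(F)(F)F)c4)c3)cc2-c2ccncc2)ccc1Cl` gives 1640 nM

All three values come from a functional assay on COLO 205 cells (Homo sapiens) for inhibition, read by sulforhodamine B assay, with a stated time of 48 h; on this read-out lower numbers stand for stronger inhibition of growth and higher numbers for weaker inhibition of growth. Compound 3 at 1640 nM lies within the usual scatter of compound 2 at 847 nM and so cannot be told apart from it. Compound 3 inhibits growth clearly more strongly than compound 1 at 7900 nM on this measure.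

Compound 4 `COc1cc(-c2nn(-c3cccc(NC(=O)c4ccc(Cl)c(C(F)(F)F)c4)c3)cc2-c2ccncc2)ccc1Cl` differs from compound 3 in one place (chloro in place of hydrogen on an aromatic carbon) with chloro in place of hydrogen on an aromatic carbon, so that 3-(trifluoromethyl)phenyl becomes 4-chloro-3-(trifluoromethyl)phenyl. Within the data shown here, no measured pair of compounds shows this change alone, so the expectation starts from compound 3 at 1640 nM and stays cautious. The expected step is a 1.5-fold lower number from compound 3 to compound 4 (0.17 log units; within the scatter) and would be small, toward a lower number, without clearly leaving the scatter. For compound 4 the estimated value is 1100 nM with an expected range from 400 nM to 3000 nM for the measurement.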

Compound 4, concentration for 50% growth inhibition: 6140 nM
Estimate against measurement, compound 4: 5.6-fold (0.75 log units) below; measured number outside the range, above it.
By their numbers in this assay, from the lowest: compounds 2 and 3 (each within the scatter of the next); then compounds 4 and 1 (each within the scatter of the next).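

Placing chloro on the outer ring of the amide, ortho to a trifluoromethyl group and para to a large group, weakens growth inhibition in this assay, with a 3.7-fold higher number from compound 3 to compound 4 (0.57 log units; beyond the scatter) as the step. A single added chlorine at this position is therefore enough to move the read-out beyond the scatter, something compounds 1, 2 and 3 could not show, as no two of them differ in only one place. Nothing available here explains this loss.

Going by these compounds, whether a fluoro, a methyl or an amine at this position would give the same result stays open. On these data alone, it is also open whether chloro here would have the same effect with the urea link of compound 2.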